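Swapping chloro for methyl on the aryl ring

This account rests on a few compounds, and the source may have more. Where it says the series, first, only, none or still open, it means among the compounds named here.

Compound 3 `CCCCN(CC)c1cc(C)nc2c1NC(=O)CN2c1ccc(Cl)cc1Br` gives 2.5 nM in an assay on HEK-293T cells for displacement of a labelled ligand from corticotropin-releasing factor receptor 1 (Homo sapiens), read by scintillation counting, with a stated time of 2 h (a higher number here means a weaker inhibitor, a lower number a stronger inhibitor), the second highest of the three numbers shown, though its steps to both neighbours lie within the scatter: compound 2 `CCCCN(CC)c1cc(C)nc2c1NC(=O)CN2c1ccc(C(C)C)cc1Br` gives 2.4 nM and compound 1 `CCCCN(CC)c1cc(C)nc2c1NC(=O)CN2c1ccc(C)cc1Cl` gives 4.4 nM. Compound 4 `CCCCN(CC)c1cc(C)nc2c1NC(=O)CN2c1ccc(C)cc1Br` has not been measured; it differs from compound 3 by methyl in place of chloro on an aromatic carbon. For the measured compounds named here, two measured steps bear on this change: a 1.0-fold higher number from compound 2 to compound 3 (0.02 log units; within the scatter), and a 1.8-fold lower number from compound 1 to compound 3 (0.25 log units; within the scatter), where compound 1 already carries a 4-methylphenyl group. Both steps stay within the scatter, so in this assay no step beyond the scatter is expected for compound 4. For compound 4 the estimate is 3.5 nM, with a range from 1.5 nM to 8 nM. This corresponds to an expected step of a 1.4-fold higher number from compound 3 to compound 4 (0.15 log units; within the scatter).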

Compound 4, inhibition constant: 4.4 nM
For compound 4 the middle estimate is 1.3-fold (0.10 log units) below the measured one, and the stated range covers the measured number.
By their numbers in this assay, from the lowest: compounds 2, 3, 1 and 4 (each within the scatter of the next).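

In this assay, methyl in place of chloro gives a 1.8-fold higher number from compound 3 to compound 4 (0.25 log units; within the scatter), and methyl in place of isopropyl on the same aromatic carbon gives a 1.8-fold higher number from compound 2 to compound 4 (0.26 log units; within the scatter), so with bromo kept, all three groups there stay within the scatter of one another. With methyl kept, bromo in place of chloro gives no change at the digits printed from compound 1 to compound 4 (within the scatter). Nothing here accounts for these results.

Going by these compounds, whether an amine or a carboxylic acid on this carbon would give a step beyond the scatter remains open. So does the outcome of replacing the bromo group with a methoxy group.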